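The source may report more compounds than this note shows. Statements on the series, on what has been measured and on what is new or still open speak of the compounds shown alone.

Compound 3 `CC(C)NCC(Cc1ccc(Cl)c(F)c1)C(=O)N1CCN(c2ncnc3c2[C@H](C)OC3)CC1` gives the lowest number of the three measured compounds in an assay on LNCaP cells for inhibition of RAC-alpha serine/threonine-protein kinase (Homo sapiens) (on this read-out higher numbers stand for weaker inhibition and lower numbers for stronger inhibition), at 315 nM. Going by the values given here, compound 1 `C[C@@H]1SCc2ncnc(N3CCN(C(=O)C(Cc4ccc(Cl)c(F)c4)CC(C)(C)N)CC3)c21` gives 587 nM in this assay, a gap that stays within the scatter; compound 2 `Cc1ccc(CC(CNC(C)C)C(=O)N2CCN(c3ncnc4c3[C@H](C)OC4)CC2)cc1` gives 995 nM, and the step of a 3.2-fold lower number from compound 2 to compound 3 (0.50 log units; beyond the scatter) is the one measured change that reaches beyond the scatter. Compound 4 `C[C@@H]1OCc2ncnc(N3CCN(C(=O)C(Cc4ccc(Cl)c(F)c4)CC(C)(C)N)CC3)c21` differs from compound 3 by 1-amino-1-methylethyl in place of isopropylamino on a saturated chain carbon, two bonds along the chain from a carbonyl carbon. Among the compounds with values here, no measured step repeats this change, so the measured steps do not show how it moves the number; compound 1, which carries the same entering group on a different core, sits within the scatter of compound 3. The expectation for compound 4 is therefore a step of a 1.6-fold higher number from compound 3 to compound 4 (0.20 log units; within the scatter), not beyond the scatter, with an estimated value of 500 nM, within 200 nM to 1300 nM.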

Compound 4, half-maximal inhibitory concentration: 592 nM
Compound 4: the middle estimate sits 1.2-fold (0.07 log units) below what was measured, and the stated range covers the measured number.
By their numbers in this assay, from the lowest: compounds 3, 1, 4 and 2 (each within the scatter of the next, the first and the last beyond it).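

Replacing isopropylamino with 1-amino-1-methylethyl on this saturated chain carbon gives a 1.9-fold higher number from compound 3 to compound 4 (0.27 log units; within the scatter) in this assay, so this assay does not separate the two amine-bearing groups. Exchanging the sulfur-containing core for the oxygen-containing one gives a 1.0-fold higher number from compound 1 to compound 4 (0.00 log units; within the scatter), so with this side chain the two cores read alike. No supporting evidence is available to explain either result. Going by these compounds, whether a carboxylic acid or a longer amine chain at this position would move the number beyond the scatter stays open. So does whether the two cores would still match when carrying isopropylamino.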